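This account rests on a few compounds, and the source may have more. Where it says the series, first, only, none or still open, it means among the compounds named here.

Compound 1 `N#CC1=C(N)OC(c2c[nH]c3ccccc23)=C(C#N)C1c1ccccc1F`: "not active" (no number reported) in a functional assay, tested at 200 ug/mL; a lower number here means a weaker effect, a higher number a stronger effect of the compound at the concentration tested. Compound 2 `COc1cc(Br)c(C2C(C#N)=C(N)OC(c3c[nH]c4ccccc34)=C2C#N)cc1OC`: 24.2%. Compound 3 `Cc1ccccc1C1C(C#N)=C(N)OC(c2c[nH]c3ccccc23)=C1C#N`: 21.4%.

All three share one core and differ only in the ring carried on its saturated ring carbon. Compound 3 sits alongside compound 2, the two values within the scatter of each other, while compound 1 gave no number at all. Compound 4 `N#CC1=C(N)OC(c2c[nH]c3ccccc23)=C(C#N)C1c1ccc(F)cc1` has not yet been tested. It differs from compound 3 in one place: 4-fluorophenyl in place of 2-methylphenyl on a saturated ring carbon. Among the measured compounds shown here, no measured pair tells how large such a change is here, so the step from compound 3 to compound 4 is expected to be small, likely none beyond the scatter, with a slight lean downward. Compound 4 is therefore estimated at 16%, between 0% and 34%, which means an expected step of a number 5.4 percentage points lower from compound 3 to compound 4 (within the scatter).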

Compound 4, a percentage reported as activity, at one concentration (the size of the read-out at that concentration, not a potency): 22.4%
For compound 4 the middle estimate is 6.4 percentage points below the measured one; measured number inside the range.
By their numbers in this assay, from the lowest: compounds 3, 4 and 2 (each within the scatter of the next).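

In this assay the swap of 2-methylphenyl for 4-fluorophenyl on the saturated ring carbon gives a number 1 percentage points higher from compound 3 to compound 4 (within the scatter) and so leaves the read-out where it was: this position takes either ring. Compound 1, also with a fluorine on its phenyl ring, is "not active" (no number reported) here, so having a fluorine on that ring does not alone settle the result. Nothing available explains this result. As far as these compounds go, whether a phenyl ring bearing an amine or a carboxylic acid would behave the same remains open, as does the effect of a longer chain in place of the ring.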